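The source may report more compounds than this note shows. Statements on the series, on what has been measured and on what is new or still open speak of the compounds shown alone.

Compounds measured so far:

Compound 1, `c1ccc(Nc2cccc(-c3nc4ccccc4s3)c2)nc1`, gives 13000 nM.
Compound 2, `CCn1c(=O)/c(=C2\Sc3cc(F)ccc3N2C)s/c1=C\c1ccncc1Nc1ccccc1F`, gives 150 nM.
Compound 3, `CCn1c(=O)/c(=C2\Sc3ccccc3N2C)s/c1=C\c1ccncc1Nc1cc(C)ccc1C`, gives 1800 nM.

In a functional assay on CWR22R cells (Homo sapiens) for inhibition (a lower number here means a stronger inhibitor, a higher number a weaker inhibitor), compound 3 stands second highest of the three numbers. Its nearest neighbour is compound 1, whose value of 13000 nM lies a good deal higher, beyond the scatter; the furthest is compound 2, whose value of 150 nM lies well lower, also beyond the scatter. Among the measured compounds shown here, compound 2 shares the core of compound 3 but differs from it in more than one place, so no single step between measured compounds can be read off.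

Compound 4, `CCn1c(=O)/c(=C2\Sc3ccccc3N2C)s/c1=C\c1ccncc1Nc1ccccc1Cl`, is the next compound to be measured. It differs from compound 3 in one place: 2-chlorophenyl in place of 2,5-dimethylphenyl on a nitrogen on an aromatic ring. For the measured compounds named here, with no measured pair showing this exact change, the expectation rests on the spread seen so far. Compound 4 is expected to sit between compound 3 and compound 2, most likely on the stronger side of compound 3, with a step of a 3.0-fold lower number from compound 3 to compound 4 (0.48 log units; beyond the scatter). For compound 4 the estimate is 600 nM, within a range from 200 nM to 2500 nM.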

Compound 4, half-maximal inhibitory concentration: 460 nM
For compound 4 the middle estimate is 1.3-fold (0.12 log units) above the measured one; the measured number falls inside the stated range.
By their numbers in this assay, from the lowest: compound 2; then compound 4; then compound 3; then compound 1.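

Among the compounds shown here, this is the first step that can be read at this place, on a nitrogen on an aromatic ring. In this assay, 2-chlorophenyl in place of 2,5-dimethylphenyl gives a 3.9-fold lower number from compound 3 to compound 4 (0.59 log units; beyond the scatter), so with the rest of the molecule unchanged, the group on this nitrogen alone moves the number beyond the scatter. Nothing given here accounts for the size or direction of this step.

The change swaps one whole group for another, with different atoms on the ring, so these compounds cannot say whether gaining the chlorine or losing the methyl groups matters more. On these data alone, how a plain phenyl, or a phenyl carrying an amine or a carboxylic acid, would compare at this place remains open.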